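Aryl amine replacement in a diaryl urea series

The source may report more compounds than this note shows. Statements on the series, on what has been measured and on what is new or still open speak of the compounds shown alone.

Measured so far in a functional assay on NCI-H520 cells (Homo sapiens) for inhibition, read by MTT assay, with a stated time of 48 h, tested at 10 uM; a lower number here means less inhibition, a higher number more inhibition at the concentration tested (going by the name of the read-out):
- compound 1 `COc1cc(NC(=O)Nc2cc(Nc3ccc(C)c(C)c3)ncn2)cc(OC)c1`: 29.5%
- compound 2 `COc1cc(NC(=O)Nc2cc(Nc3ccc(C)c(F)c3)ncn2)cc(OC)c1`: 30.6%
- compound 3 `COc1ccc(C(F)(F)F)cc1Nc1cc(NC(=O)Nc2c(Cl)cccc2Cl)ncn1`: 33%

Compound 2 stands second highest of the three numbers in this assay; its nearest neighbour is compound 1 and its furthest is compound 3, and both gaps lie within the scatter, so the three measured compounds cannot be told apart on these values.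

Compound 4 `COc1cc(NC(=O)Nc2cc(Nc3cc(I)ccc3OC)ncn2)cc(OC)c1` is not yet measured. Against compound 2 the change is 5-iodo-2-methoxyphenyl in place of 3-fluoro-4-methylphenyl on a nitrogen on an aromatic ring. Among the compounds with values here, the only measured step on that same ring is a number 1.1 percentage points higher from compound 1 to compound 2 (within the scatter), which lies within the scatter. Within the data shown here, no measured step exchanges the whole aryl group, so the expectation for compound 4 rests on the narrow spread of all three measured values rather than on a directly comparable step; no step beyond the scatter is expected in this assay, but the range is kept wide.

Compound 4 is estimated at 31%, between 17% and 46%. The expected step is a number 0.4 percentage points higher from compound 2 to compound 4 (within the scatter).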

Compound 4, a percentage reported as inhibition, at one concentration (the size of the read-out at that concentration, not a potency): 55%
Compound 4: the middle estimate sits 24 percentage points below what was measured, outside the stated range (above it).
By their numbers in this assay, from the lowest: compounds 1, 2 and 3 (each within the scatter of the next); then compound 4.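

In this assay, the aryl group on a nitrogen on an aromatic ring now proves able to shift the read-out: 5-iodo-2-methoxyphenyl in place of 3-fluoro-4-methylphenyl gives a number 24.4 percentage points higher from compound 2 to compound 4 (beyond the scatter), and in place of 3,4-dimethylphenyl it gives a number 25.5 percentage points higher from compound 1 to compound 4 (beyond the scatter). Within the data shown here, the only earlier step at this position, fluoro in place of methyl, gave a number 1.1 percentage points higher from compound 1 to compound 2 (within the scatter), so this position shows a response only once the whole aryl group is exchanged. No measurement at hand accounts for the size of these steps.

The iodo and methoxy groups enter together, so the compounds shown do not separate what each contributes to the higher number. As far as these compounds go, whether a bromo group or a nitrile in place of the iodo would hold that number also remains open.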